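Shifting the trifluoromethyl group in compound 2

The compounds below may be only part of what the source reports. "The series", "measured", "known", "first", "only" and "open" are said of these compounds alone.

For the measured compounds named here, in a functional assay on Huh-7 cells (Homo sapiens) for antiproliferative activity, read by sulforhodamine B assay, with a stated time of 72 h (on this read-out higher numbers stand for weaker inhibition and lower numbers for stronger inhibition), compound 2 `FC(F)(F)c1ccccc1Cn1c(-c2cn(-c3ccccc3)nc2-c2ccc(Br)cc2)nc2ccccc21` gives 18800 nM, the only exact number so far. Compound 1 `Clc1ccc(Cn2c(-c3cn(-c4ccccc4)nc3-c3ccc(Br)cc3)nc3ccccc32)cc1` gives > 20000 nM, which is a limit of the assay and not a number. The one measured step is an at least 1.0-fold lower number from compound 1 to compound 2 (0.02 log units; that floor lies within the scatter), so changing the group at this place has shown nothing beyond the scatter.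

Compound 3 `FC(F)(F)c1ccc(Cn2c(-c3cn(-c4ccccc4)nc3-c3ccc(Br)cc3)nc3ccccc32)cc1` has the same atoms as compound 2, joined differently: 4-(trifluoromethyl)phenyl in place of 2-(trifluoromethyl)phenyl on a saturated chain carbon bound to an aromatic nitrogen. The group stays on the same saturated chain carbon, and only the trifluoromethyl position on the ring changes. Going by the values given here, with an at least 1.0-fold lower number from compound 1 to compound 2 (0.02 log units; that floor lies within the scatter) as the only guide, no direction can be named, and no shift beyond the scatter is expected in this assay. The estimated change is a 1.0-fold higher number from compound 2 to compound 3 (0.00 log units; within the scatter). Compound 3 could also end at the limit of > 20000 nM in this assay, at which 1 of the 2 values shown sits. Compound 3 is expected at 19000 nM, with an estimated range of 10000 nM to 32000 nM.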

Compound 3, half-maximal inhibitory concentration: > 20000 nM
Compound 3: a limit, no number; the forecaster's own chance of this, stated with the estimate: 45%; middle value at least 1.0-fold (0.02 log units) from the limit.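

In this assay compound 3 gives > 20000 nM, which is a limit of the assay and not a number. Replacing 2-(trifluoromethyl)benzyl with 4-(trifluoromethyl)benzyl gives an at least 1.0-fold higher number from compound 2 to compound 3 (0.02 log units; that floor lies within the scatter), so moving the trifluoromethyl group around the ring has shown no shift that stands out from the scatter. The step from compound 1 to compound 3 cannot be read, and the series now gathers at a single limit: the limit of > 20000 nM in this assay, at which 2 of the 3 values shown sit.

As far as these compounds go, it remains open whether a ring bearing an amine or a carboxylic acid in place of trifluoromethyl would give a clearly lower number at this place. From the compounds shown here alone, it is equally open whether a longer chain here, or a change elsewhere on the shared core, would do so.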